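The source may hold more compounds than are shown below. What is called first, only, known or untested is meant among the compounds shown, and "the series" means these compounds.

Working notes on the amide series, followed in a functional assay on BXPC-3 cells (Homo sapiens) for antiproliferative activity, read by MTT assay, with a stated time of 24 h; a lower number here means a stronger inhibitor, a higher number a weaker inhibitor. Compound 1 `CCn1c(C(=O)N[C@@H](CC(=O)OC)C(=O)OC)ccc1C(CC)(CC)c1ccc(OCS(=O)(=O)c2ccccc2)c(C)c1` gives > 50000 nM, which is a limit of the assay and not a number. Going by the values given here, compound 2 `CCn1c(C(=O)NCCN)ccc1C(CC)(CC)c1ccc(OCS(=O)(=O)c2ccccc2)c(C)c1` gives 6430 nM, the only true number so far.

Compound 3 `CCn1c(C(=O)N[C@H](CO)C(C)C)ccc1C(CC)(CC)c1ccc(OCS(=O)(=O)c2ccccc2)c(C)c1` changes the group on the amide-type nitrogen of compound 2, with 1-(hydroxymethyl)-2-methylpropyl in place of 2-aminoethyl on an amide-type nitrogen.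

Among the compounds with values here, the one measured step at this nitrogen is an at least 7.7-fold lower number from compound 1 to compound 2 (0.89 log units; beyond the scatter). It is beyond the scatter and at least modest, and it brought in the 2-aminoethyl that compound 3 loses. A single step is thin support, but it points towards a partial reversal. The estimated change is a 2.8-fold higher number from compound 2 to compound 3 (0.45 log units; beyond the scatter), towards a higher number and so a weaker result in this assay. A limit reading remains possible. For compound 3 the expected value is 18000 nM, with an estimated range of 5000 nM to 50000 nM.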

Compound 3, half-maximal inhibitory concentration in the BXPC-3 assay: 7720 nM
The estimate for compound 3 lay 2.3-fold (0.37 log units) above the measured number; measured number inside the range.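

Going by these compounds alone, at the amide-type nitrogen, in the BXPC-3 assay, 1-(hydroxymethyl)-2-methylpropyl in place of 2-aminoethyl gives a 1.2-fold higher number from compound 2 to compound 3 (0.08 log units; within the scatter), and compound 3 at 7720 nM shows that 2-aminoethyl is not the only group here that gives a true number. A second group now clears the limit in the BXPC-3 assay, with an at least 6.4-fold lower number from compound 1 to compound 3 (0.81 log units; beyond the scatter), a step that starts from a limit of the assay and not from a number. The two groups do separate in a physicochemical assay for solubility, read by HPLC, at pH 7.4 (a lower number here means a less soluble compound, a higher number a more soluble compound), with a 2.3-fold lower number from compound 2 to compound 3 (0.37 log units; beyond the scatter). In the physicochemical assay compound 2 gives 65 ug/mL and compound 3 gives 27.8 ug/mL.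

The compounds shown leave open whether a carboxylic acid or a longer chain on this nitrogen would move the number in the BXPC-3 assay beyond the scatter. Also open is whether the defined stereocentre of 1-(hydroxymethyl)-2-methylpropyl matters, since its mirror-image form is not among the compounds shown.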